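Trifluoromethyl for Methyl on the Benzyl Ring

The compounds below may be only part of what the source reports. "The series", "measured", "known", "first", "only" and "open" are said of these compounds alone.

Three compounds have been measured in an assay on microsomes from liver for inhibition of 3-hydroxy-3-methylglutaryl-coenzyme A reductase (Rattus norvegicus); on this read-out higher numbers stand for weaker inhibition and lower numbers for stronger inhibition:
Compound 1, `CC(C)c1c(C(=O)N(C)Cc2cccc(F)c2)nn(-c2ccc(F)cc2)c1OC[C@@H](O)C[C@@H](O)CC(=O)O`, gives 14 nM.
Compound 2, `CC(C)c1c(C(=O)N(C)Cc2cccc(Cl)c2)nn(-c2ccc(F)cc2)c1OC[C@@H](O)C[C@@H](O)CC(=O)O`, gives 8.3 nM.
Compound 3, `Cc1cccc(CN(C)C(=O)c2nn(-c3ccc(F)cc3)c(OC[C@@H](O)C[C@@H](O)CC(=O)O)c2C(C)C)c1`, gives 37 nM.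

Compound 3 stands at the highest number of the three. The two steps leading to it are both beyond the scatter: a 2.6-fold higher number from compound 1 to compound 3 (0.42 log units; beyond the scatter) and a 4.5-fold higher number from compound 2 to compound 3 (0.65 log units; beyond the scatter). The step between the two halogen compounds, a 1.7-fold lower number from compound 1 to compound 2 (0.23 log units; within the scatter), lies within the scatter, so those two cannot be ordered against each other.

Compound 4, `CC(C)c1c(C(=O)N(C)Cc2cccc(C(F)(F)F)c2)nn(-c2ccc(F)cc2)c1OC[C@@H](O)C[C@@H](O)CC(=O)O`, differs from compound 3 in one place: trifluoromethyl in place of methyl on an aromatic carbon. Among the measured compounds shown here, no measured step exchanges methyl for trifluoromethyl, so the bearing steps are the two in which methyl stood against a halogen on that same aromatic carbon. Read in the direction toward compound 3, both raised the number modestly; read back from compound 3, both lower it. Because compound 3 sits at 37 nM and the steps of a 2.6-fold higher number from compound 1 to compound 3 (0.42 log units; beyond the scatter) and a 4.5-fold higher number from compound 2 to compound 3 (0.65 log units; beyond the scatter) show that the other groups tried in that place gave lower numbers, a modest lowering is expected here as well, with the size uncertain. Compound 4 is therefore estimated at 15 nM, within a range of 5 nM to 45 nM, corresponding to an expected step of a 2.5-fold lower number from compound 3 to compound 4 (0.39 log units; beyond the scatter).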

Compound 4, half-maximal inhibitory concentration: 31 nM
For compound 4 the middle estimate is 2.1-fold (0.32 log units) below the measured one, and the stated range covers the measured number.
By their numbers in this assay, from the lowest: compounds 2 and 1 (each within the scatter of the next); then compounds 4 and 3 (each within the scatter of the next).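

In this assay, trifluoromethyl in place of methyl on this aromatic carbon gives a 1.2-fold lower number from compound 3 to compound 4 (0.08 log units; within the scatter), so compound 3 and compound 4 cannot be ordered against each other, and the higher number at this position is no longer seen with methyl alone. Against the halogens, trifluoromethyl stands apart as methyl did, with a 3.7-fold higher number from compound 2 to compound 4 (0.57 log units; beyond the scatter) and a 2.2-fold higher number from compound 1 to compound 4 (0.35 log units; beyond the scatter), so the four compounds fall into two sets: fluoro and chloro on one side, methyl and trifluoromethyl on the other, with no compound shown going against this split. Nothing at hand gives a measured reason for the split.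

The compounds shown leave open whether a methoxy group, a nitrile, an amine or a bromo substituent on the same aromatic carbon would fall with the halogens, with methyl and trifluoromethyl, or with neither. They also leave open whether the same split would appear if the isopropyl group or the 4-fluorophenyl group of the shared core were replaced by another group, since all four compounds carry that core unchanged.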